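A methylpiperazine chain on the core of compound 1

The compounds below may be only part of what the source reports. "The series", "measured", "known", "first", "only" and "open" are said of these compounds alone.

Compound 1 `CN(C)CCn1c(N)c(-c2nc3ccccc3[nH]2)c2nc(C#N)c(C#N)nc21` gives 2220 nM
Compound 2 `CCCn1c(N)c(-c2nc3ccccc3[nH]2)c2nc(C#N)c(C#N)nc21` gives 45200 nM
Compound 3 `CCN(CC)CCCn1c(N)c(-c2nc3ccccc3[nH]2)c2nc(C#N)c(C#N)nc21` gives > 730 nM (a limit)

In a functional assay on HL-60 cells (Homo sapiens) for antiproliferative activity, read by MTT assay, with a stated time of 48 h (a lower number here means a stronger inhibitor, a higher number a weaker inhibitor), compound 1 has the lower of the two values that are true numbers. Compound 3 gives only a limit, so a step that the limit leaves unreadable from compound 1 to compound 3 adds nothing on size, and a step that the limit leaves unreadable from compound 2 to compound 3 adds nothing either.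

Compound 4 `CN1CCN(CCCn2c(N)c(-c3nc4ccccc4[nH]3)c3nc(C#N)c(C#N)nc32)CC1` carries (4-methylpiperazin-1-yl)methyl in place of dimethylamino on a saturated chain carbon, two bonds along the chain from an aromatic nitrogen. The same difference reads 2-(dimethylamino)ethyl to 3-(4-methylpiperazin-1-yl)propyl.

Compound 4 keeps an amine at the end of its chain, so the large step of a 20-fold higher number from compound 1 to compound 2 (1.31 log units; beyond the scatter) that puts methyl in place of dimethylamino is not expected to repeat. The expected step is a 1.4-fold higher number from compound 1 to compound 4 (0.13 log units; within the scatter) in this assay (no change beyond the scatter is expected). The estimated value of compound 4 is 3000 nM (expected range 800 nM to 12000 nM).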

Compound 4, half-maximal inhibitory concentration: 750 nM
Beside the measured number, compound 4's estimate is 4.0-fold (0.60 log units) above it; measured number outside the range, below it.
By their numbers in this assay, from the lowest: compound 4; then compound 1; then compound 2.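

In this assay, this position accepts a much larger end group than dimethylamino: the move to the 3-(4-methylpiperazin-1-yl)propyl chain gives a 3.0-fold lower number from compound 1 to compound 4 (0.47 log units; beyond the scatter). The ring therefore does more than hold the activity of the shorter amine chain, and it brings one hetero atom more into the group. Set against the plain propyl chain, the 4-methylpiperazin-1-yl group gives a 60-fold lower number from compound 2 to compound 4 (1.78 log units; beyond the scatter), so both chains with a readable value that end in an amine stand well clear of the chain without one.

Compound 3 gives only a limit, and none of its steps to the other compounds can be read: the limit of > 730 nM in this assay, at which 1 of the 4 values shown sits.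

In compound 4 the chain length and the end group change together, and a 3-(dimethylamino)propyl chain would tell the two apart.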